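A few compounds are considered here, and "the series" means these few. Any claim that something is new, unique, unknown or untested is made for them only; others in the source may bear on it.

Measured compounds:
compound 1 `CCCCOc1nc(C(C)(C)C)ccc1CNC(=O)C(C)c1ccc(NS(C)(=O)=O)c(F)c1` gives 0.9 nM
compound 2 `CCCCCCSc1nc(C(C)(C)C)ccc1CNC(=O)C(C)c1ccc(NS(C)(=O)=O)c(F)c1` gives 1.5 nM
compound 3 `CC(C(=O)NCc1ccc(C(C)(C)C)nc1SCCCN1CCCC1)c1ccc(NS(C)(=O)=O)c(F)c1` gives 17.1 nM

All three were tested in an assay on cells for antagonist activity at transient receptor potential cation channel subfamily V member 1 (Homo sapiens), read by FLIPR and calcium flux, with a stated time of 6 min; on this read-out lower numbers stand for stronger inhibition and higher numbers for weaker inhibition. Compound 1 has the lowest number of the three; compound 2 is nearest to it, and the step of a 1.7-fold higher number from compound 1 to compound 2 (0.22 log units; within the scatter) lies within the scatter, while compound 3 is furthest, the step of a 19-fold higher number from compound 1 to compound 3 (1.28 log units; beyond the scatter) being well beyond it. The new compound is compound 4 `CC(C(=O)NCc1ccc(C(C)(C)C)nc1SCc1ccccc1Cl)c1ccc(NS(C)(=O)=O)c(F)c1`. Against compound 1 it differs in one place: (2-chlorobenzyl)sulfanyl in place of butoxy on an aromatic carbon. Among the measured compounds shown here, two measured steps bear on this. The step of a 1.7-fold higher number from compound 1 to compound 2 (0.22 log units; within the scatter) shows that replacing the butoxy by a sulfur-linked chain costs little. The step of a 19-fold higher number from compound 1 to compound 3 (1.28 log units; beyond the scatter) and the step of an 11-fold higher number from compound 2 to compound 3 (1.06 log units; beyond the scatter) show that putting pyrrolidin-1-yl at the end of the sulfur-linked chain costs a lot, but compound 4 carries no pyrrolidin-1-yl, so that loss need not carry over. The (2-chlorobenzyl)sulfanyl group is larger than either chain, and nothing measured here has a ring in this position, so a modest rise in this assay is expected rather than a large one. For compound 4 the expected step is a 3.3-fold higher number from compound 1 to compound 4 (0.52 log units; beyond the scatter), giving an estimate of 3 nM with a range from 0.8 nM to 12 nM.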

Compound 4, inhibition constant: 3.8 nM
Compound 4: middle estimate off by 1.3-fold (0.10 log units), on the low side; low and high end bracket the measured number.
By their numbers in this assay, from the lowest: compounds 1 and 2 (each within the scatter of the next); then compound 4; then compound 3.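

In this assay, the (2-chlorobenzyl)sulfanyl group gives a 4.2-fold higher number from compound 1 to compound 4 (0.63 log units; beyond the scatter), so this position accepts a group carrying an aromatic ring at a modest cost. Placing 2-chlorophenyl in place of pentyl on the carbon bound to sulfur gives a 2.5-fold higher number from compound 2 to compound 4 (0.40 log units; beyond the scatter), a small but real loss, whereas the earlier change from butoxy to hexylsulfanyl stayed within the scatter. Placing 2-chlorophenyl in place of 2-(pyrrolidin-1-yl)ethyl gives a 4.5-fold lower number from compound 3 to compound 4 (0.65 log units; beyond the scatter), so the ring-bearing group falls between the plain chain and the chain ending in pyrrolidine.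

Nothing measured here explains these differences. Still open, as far as these compounds go, is what the chlorine contributes, which a plain benzylsulfanyl group would show, and how a benzyloxy group or a chain ending in a carboxylic acid would compare.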